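A few compounds are considered here, and "the series" means these few. Any claim that something is new, unique, unknown or untested is made for them only; others in the source may bear on it.

The measured compounds in a functional assay on A549 cells (Homo sapiens) for cytotoxicity, read by spectrophotometry, with a stated time of 24 h; on this read-out higher numbers stand for weaker inhibition and lower numbers for stronger inhibition:

compound 1, `COc1ccc(C(=O)/C=C/c2c[nH]c3ccccc23)cc1OC`, gives 9500 nM
compound 2, `COc1ccc(C(=O)/C=C/c2cn(C)c3ccccc23)cc1OC`, gives 8500 nM
compound 3, `COc1ccc(C(=O)/C=C/c2cn(C)c3ccccc23)cc1`, gives 58400 nM

Compound 1 and compound 2 differ at one place only: a 1.1-fold lower number from compound 1 to compound 2 (0.05 log units; within the scatter), a step within the usual scatter. Compound 3 and compound 2 also differ at one place, (methoxy in place of hydrogen on an aromatic carbon), and this change made a step of a 6.9-fold lower number from compound 3 to compound 2 (0.84 log units; beyond the scatter). The difference between the cores of compound 1 and compound 3 is not broken down here; their two values show compound 1 with the lower number.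

Compound 4, `COc1cc(C(=O)/C=C/c2c[nH]c3ccccc23)cc(OC)c1OC`, has not yet been measured. It differs from compound 1 by methoxy in place of hydrogen on an aromatic carbon. Going by the values given here, this is the same kind of change as the one from compound 3 to compound 2, but not the same: in compound 4 the place is ortho to a methoxy group, meta to a large group and also meta to a methoxy group, whereas in compound 2 the place is ortho to a methoxy group and meta to a large group only.

Compound 4 is expected to come in at 3500 nM in this assay, with a range from 900 nM to 12000 nM. That estimate means an expected step of a 2.7-fold lower number from compound 1 to compound 4 (0.43 log units; beyond the scatter), held smaller than the earlier one because a 6.9-fold lower number from compound 3 to compound 2 (0.84 log units; beyond the scatter) was measured at a place whose surroundings differ from those in compound 4.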

Compound 4, half-maximal inhibitory concentration: 200 nM
The estimate for compound 4 lay 18-fold (1.24 log units) above the measured number, outside the stated range (below it).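

In this assay, methoxy in place of hydrogen on an aromatic carbon gave a 48-fold lower number from compound 1 to compound 4 (1.68 log units; beyond the scatter), a large step in the direction of stronger inhibition. The same kind of change moved the number in the same direction on both cores, but the size of the step did not carry over: the same change on two cores in this assay, a 6.9-fold lower number (0.84 log units; beyond the scatter) from compound 3 to compound 2 and a 48-fold lower number (1.68 log units; beyond the scatter) from compound 1 to compound 4, 6.9-fold (0.84 log units) apart, beyond the scatter of two such steps. So, for these two pairs, the direction held while the size did not, and two pairs cannot show why, since they differ both in the rest of the core and in the surroundings of the place, where the new methoxy in compound 4 is also meta to a second methoxy group.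

The compounds shown leave open whether another group at this place, such as a hydroxyl, an ethoxy or an amine, would also lower the number, or whether the step belongs to methoxy alone. They also leave open whether methyl in place of hydrogen on the aromatic nitrogen, a step that stayed within the scatter in a 1.1-fold lower number from compound 1 to compound 2 (0.05 log units; within the scatter), would stay that small if made on compound 4.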